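A few compounds are considered here, and "the series" means these few. Any claim that something is new, unique, unknown or untested is made for them only; others in the source may bear on it.

Three compounds have so far been tested in a functional assay on the whole organism with Rattus norvegicus as the target, read by paw edema, with a stated time of 3 h, at a dose of 100 mg/kg by the oral route; a higher number here means more inhibition at the dose given (going by the name of the read-out), a lower number less inhibition:

compound 1 `CCc1cccc(-c2nc3ccccc3[nH]2)n1` gives 41%
compound 2 `CCCCc1ccc(-c2nc3ccccc3[nH]2)nc1` gives -16%
compound 3 `CCOC(=O)c1cccc(-c2nc3ccccc3[nH]2)n1` gives 31%

Compound 3 stands second highest of these three numbers. Its nearest neighbour is compound 1: the step from compound 1 to compound 3 was a number 10 percentage points lower from compound 1 to compound 3 (within the scatter), which lies within the scatter, so the two cannot be ordered. Among the compounds with values here, the furthest is compound 2, whose value in this assay lies far below that of compound 3, well beyond the scatter; no single-point step connects these two, so only the two values themselves are known.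

The next compound, compound 4 `COc1cccc(-c2nc3ccccc3[nH]2)n1`, differs from compound 3 as follows:

methoxy in place of ethoxycarbonyl on an aromatic carbon

Within the data shown here, only one measured step touches the same aromatic carbon: the exchange of ethyl for ethoxycarbonyl from compound 1 to compound 3, which gave a number 10 percentage points lower from compound 1 to compound 3 (within the scatter). Among the measured compounds shown here, no measured step introduces a methoxy group, so the data give no direct guide for this change. For the measured compounds named here, since the one step at this position stayed within the scatter, the change to compound 4 is expected to give a step of a number 1 percentage points lower from compound 3 to compound 4 (within the scatter), that is, none beyond the scatter. Compound 4 is therefore estimated at 30% in this assay, with a range from 5% to 50%.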

Compound 4, a percentage reported as inhibition, in the whole organism at one dose (the size of the read-out at that dose, not a potency): 47%
For compound 4 the middle estimate is 17 percentage points below the measured one; measured number inside the range.
By their numbers in this assay, from the lowest: compound 2; then compounds 3, 1 and 4 (each within the scatter of the next, the first and the last beyond it).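

In this assay, the position on the aromatic carbon next to the ring nitrogen now shows a change that can be read: with methoxy, of 2 heavy atoms, in place of ethoxycarbonyl, of 5 heavy atoms, the result is a number 16 percentage points higher from compound 3 to compound 4 (beyond the scatter), a modest step but the first at this position beyond the scatter. Methoxy in place of ethyl gives a number 6 percentage points higher from compound 1 to compound 4 (within the scatter), so those two groups cannot be ordered here, and since the ethyl to ethoxycarbonyl step also stayed within the scatter, methoxy and ethoxycarbonyl are the only pair at this position that the data separate. The data offer no measured basis for explaining why this one exchange goes beyond the scatter.

The compounds shown leave open how an amine, a carboxylic acid or a longer chain on this same carbon would compare with methoxy, and whether any group here would clearly separate from both methoxy and ethyl. They also leave open how the placement of a substituent matters, since compound 2 differs from the others in more than one place and offers no single-place comparison.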